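Phenyl for Methyl: Forecasting Aromatase Inhibition of Compound 4

A few compounds are considered here, and "the series" means these few. Any claim that something is new, unique, unknown or untested is made for them only; others in the source may bear on it.

Measured in an assay on isolated protein for inhibition of Aromatase (Homo sapiens), read by fluorescence and colorimetric assay, with a stated time of 30 min; a higher number here means a weaker inhibitor, a lower number a stronger inhibitor:

Compound 1, `Cc1ccc(OCc2cn(C(c3ccccc3)c3ccccc3)nn2)cc1`: 26800 nM
Compound 2, `c1ccc(-c2ccc(OCc3cn(C(c4ccccc4)c4ccccc4)nn3)cc2)cc1`: 15500 nM
Compound 3, `Cc1ccc(OCc2cn(Cc3ccc(C#N)cc3)nn2)cc1`: 4170 nM

Compound 1 and compound 2 share one core and differ only by phenyl in place of methyl on an aromatic carbon. That change produced a 1.7-fold lower number from compound 1 to compound 2 (0.24 log units; within the scatter). Compound 3 rests on a different core; the difference between the two cores is not broken down here. Among the three, compound 3 gives the lowest number, with its steps to the other two beyond the scatter.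

Compound 4, `N#Cc1ccc(Cn2cc(COc3ccc(-c4ccccc4)cc3)nn2)cc1`, has not yet been measured. It differs from compound 3 by phenyl in place of methyl on an aromatic carbon, the same change seen between compound 1 and compound 2. The step in this assay is estimated at a 1.7-fold lower number from compound 3 to compound 4 (0.22 log units; within the scatter) because the same change earlier gave a 1.7-fold lower number from compound 1 to compound 2 (0.24 log units; within the scatter). Compound 4 is therefore expected to show about 2500 nM, with a likely range from 900 nM to 7000 nM.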

Compound 4, half-maximal inhibitory concentration: 11600 nM
For compound 4 the middle estimate is 4.6-fold (0.67 log units) below the measured one; the measured number lies above the stated range.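

In this assay, phenyl in place of methyl on an aromatic carbon gave a 2.8-fold higher number from compound 3 to compound 4 (0.44 log units; beyond the scatter) and so did not repeat the earlier step. The result of this change differs between the two cores: the same change on two cores in this assay, a 1.7-fold lower number (0.24 log units; within the scatter) from compound 1 to compound 2 and a 2.8-fold higher number (0.44 log units; beyond the scatter) from compound 3 to compound 4, 4.8-fold (0.68 log units) apart, beyond the scatter of two such steps

This shows that a step seen on one core could not simply be copied onto the other in this series. Going by these compounds alone, with only two pairs it gives no general rule for other cores, and it does not show which part of the cores accounts for the difference.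

The compounds shown carry only methyl or phenyl at this place. Going by these compounds, how a methoxy group, an amine or a carboxylic acid there would behave on either core remains open.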